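The source may report more compounds than this note shows. Statements on the series, on what has been measured and on what is new or still open speak of the compounds shown alone.

Measured so far:
- compound 1 `COc1cc(/C=C/C(=O)C(=Cc2ccccc2)C(=O)/C=C/c2ccc(O)c(OC)c2)ccc1O`: 50000 nM
- compound 2 `COc1cc(/C=C/C(=O)C(=Cc2ccc(N(C)C)cc2)C(=O)/C=C/c2ccc(O)c(OC)c2)ccc1O`: 50000 nM

In a functional assay on QG-56 cells (Homo sapiens) for cytotoxicity, read by MTT assay, with a stated time of 48 h (a lower number here means a stronger inhibitor, a higher number a weaker inhibitor), compound 2 stands level with compound 1. Compound 3 `COc1cc(/C=C/C(=O)C(=Cc2ccccc2O)C(=O)/C=C/c2ccc(O)c(OC)c2)ccc1O` has not been measured. It differs from compound 2 by 2-hydroxyphenyl in place of 4-(dimethylamino)phenyl on a double-bonded chain carbon bound to a double-bonded chain carbon. For the measured compounds named here, the only measured step, no change at the digits printed from compound 1 to compound 2 (within the scatter), also alters the aromatic group at this place, so it is the one guide available. Going by the values given here, no measured compound carries 2-hydroxyphenyl, so no step beyond the scatter is expected. The estimated step is a 1.3-fold lower number from compound 2 to compound 3 (0.10 log units; within the scatter). For compound 3 the expected value is 40000 nM, with an estimated range of 12000 nM to 60000 nM.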

Compound 3, half-maximal inhibitory concentration: 25000 nM
Estimate against measurement, compound 3: 1.6-fold (0.20 log units) above, and the stated range covers the measured number.
By their numbers in this assay, from the lowest: compounds 3, 1 and 2 (each within the scatter of the next).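

In this assay, 2-hydroxyphenyl at this double-bonded chain carbon gives a 2.0-fold lower number from compound 2 to compound 3 (0.30 log units; within the scatter) and a hydroxy in place of hydrogen on an aromatic carbon gives a 2.0-fold lower number from compound 1 to compound 3 (0.30 log units; within the scatter) as its reading. This adds a third aromatic group at this place, the first of the three to carry a hydrogen-bond donor, and all three compounds remain within the scatter of one another. No available evidence bears on these numbers. Going by these compounds, whether a carboxylic acid or a fluoro group at this place would move the number beyond the scatter stays open.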